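The source may hold more compounds than are shown below. What is called first, only, known or untested is meant among the compounds shown, and "the series" means these compounds.

Of the compounds shown here, three on one shared core have been measured in an assay on isolated protein for inhibition of MAP kinase-activated protein kinase 5 (Homo sapiens), tested at 1 uM; on this read-out higher numbers stand for more inhibition at the one concentration tested (going by the name of the read-out) and lower numbers for less inhibition. Compound 1 `CCNCc1ccc(N/C(=C2\C(=O)Nc3cc(C(=O)N(C)CC)ccc32)c2ccccc2)cc1` gives 70% in this assay. Compound 2 `CN(C)C(=O)c1ccc2c(c1)/C(=C(/Nc1ccc(CN3CCCCC3)cc1)c1ccccc1)C(=O)N2` gives 59% in this assay. Compound 3 `CCNC(=O)c1ccc2c(c1)NC(=O)/C2=C(\Nc1ccc(CN(C)C)cc1)c1ccccc1` gives 96% in this assay. On these three numbers compound 2 stands lowest: its gap to compound 1 is beyond the scatter, and its gap to compound 3 is wider still, also beyond the scatter. Among the measured compounds shown here, no two of the measured compounds differ in one place only, so no single step has been measured within the set so far.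

Compound 4 `O=C1Nc2ccccc2/C1=C(/Nc1ccc(CN2CCCCC2)cc1)c1ccccc1` has not yet been measured in this assay. It differs from compound 2 in one place: hydrogen in place of dimethylcarbamoyl on an aromatic carbon. Each measured compound carries a substituent at the place where compound 4 carries hydrogen, so there is no measured guide for its removal; the reading of compound 2 at 59% is the only anchor. The step expected in this assay is a number 24 percentage points lower from compound 2 to compound 4 (beyond the scatter), downward and beyond the scatter, with wide uncertainty. Compound 4 is estimated at 35% in this assay, with a range from 5% to 70%.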

Compound 4, a percentage reported as inhibition, at one concentration (the size of the read-out at that concentration, not a potency): 38%
The estimate for compound 4 lay 3 percentage points below the measured number; the range from low to high includes it.
By their numbers in this assay, from the lowest: compound 4; then compound 2; then compound 1; then compound 3.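

In this assay, among the compounds shown here, the one step read at this position is a number 21 percentage points lower from compound 2 to compound 4 (beyond the scatter), with hydrogen in place of dimethylcarbamoyl on an aromatic carbon and the rest of the structure unchanged. Every earlier compound carried a substituent at this place and differed from the others in more than one place, so the effect of this position could not be separated from changes elsewhere; this pair shows that the read-out responds to the change at this place alone, and that dimethylcarbamoyl here goes with more inhibition than hydrogen at the one concentration tested. No measurement shown bears on what lies behind this step.

Steps among compound 1, compound 2 and compound 3 cannot be read, so it remains open whether the size of this step holds when the rest of the molecule differs, or whether the carbamoyl substitution itself affects the read-out. Also open, going by these compounds, is how smaller or differently built groups at this aromatic carbon, such as a primary carboxamide, a carboxylic acid, a nitrile or a methoxy group, would compare with dimethylcarbamoyl and hydrogen.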